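The source may report more compounds than this note shows. Statements on the series, on what has been measured and on what is new or still open speak of the compounds shown alone.

Notes on the series in a functional assay on KB cells (Homo sapiens) for inhibition, read by sulforhodamine B assay, with a stated time of 72 h; a lower number here means a stronger inhibitor of growth, a higher number a weaker inhibitor of growth. Compound 1 `CCOC(=O)/C=C/c1ccncc1-c1ccc2ccccc2c1` reads > 10000 nM, which is a limit of the assay. Compound 2 `CCOC(=O)/C=C/c1ccncc1-c1ccc2c(ccn2C)c1` gives a real number, 6250 nM. Compound 3 `Cn1ccc2cc(-c3cnccc3/C=C/C(=O)O)ccc21` reads > 10000 nM, which is also a limit and not a number. Compound 3 therefore stands at the limit of > 10000 nM in this assay, at which 2 of the 3 values shown sit, so its true value is not known.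

Compound 4 `CNC(=O)/C=C/c1ccncc1-c1ccc2c(ccn2C)c1` is reached from compound 3 by methylamino in place of hydroxy on a carbonyl carbon, turning 2-carboxyethenyl into 2-(methylcarbamoyl)ethenyl. For the measured compounds named here, the only measured step at this carbonyl is an at least 1.6-fold higher number from compound 2 to compound 3 (0.20 log units; that floor lies within the scatter), a change of a different group and bounded on one side only, so it gives weak guidance on size. Nothing measured points to a clear gain in this assay, and a further limit reading is quite possible. The estimated change is an at least 1.1-fold lower number from compound 3 to compound 4 (0.04 log units; that floor lies within the scatter), and no step beyond the scatter is expected. For compound 4 the expected value is 9000 nM, with an estimated range of 3500 nM to 20000 nM.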

Compound 4, concentration for 50% growth inhibition: 7080 nM
Compound 4: middle estimate off by 1.3-fold (0.10 log units), on the high side, and the stated range covers the measured number.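

In this assay this carbonyl now has a second real reading: a 1.1-fold higher number from compound 2 to compound 4 (0.05 log units; within the scatter) is the whole of methylamino in place of ethoxy, so these two groups are not told apart at this position. Methylamino in place of hydroxy reads as an at least 1.4-fold lower number from compound 3 to compound 4 (0.14 log units; that floor lies within the scatter) and this one-sided figure gives no size for the change. That step stays a floor because compound 3 is a limit of the assay and not a number: the limit of > 10000 nM in this assay, at which 2 of the 4 values shown sit.

Open, going by these compounds, is the true size of the change from hydroxy to methylamino, and whether a plain amino group, a dimethylamino group or a longer alkylamino chain on this carbonyl reads differently in this assay. Also open, on these data alone, is how a saturated ethyl chain in place of the ethenyl part would read.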